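Swapping fluoro for chloro on compound 3

A few compounds are considered here, and "the series" means these few. Any claim that something is new, unique, unknown or untested is made for them only; others in the source may bear on it.

Values from a functional assay on NCI-H460 cells (Homo sapiens) for inhibition, read by sulforhodamine B assay, with a stated time of 48 h (on this read-out lower numbers stand for stronger inhibition of growth and higher numbers for weaker inhibition of growth), are these so far:
- Compound 1 (`CCOC(=O)c1nn(-c2ccccc2)c(-c2ccc(F)cc2)c1CNC(C)(C)C`) gives 365000 nM; 179000 nM (2 entries) as two numbers
- Compound 2 (`CCOC(=O)c1nn(-c2ccccc2)c(-c2ccc(Cl)cc2)c1CNC(C)(C)C`) gives 69200 nM; > 559000 nM (2 entries)
- Compound 3 (`CC(C)(C)NCc1c(C(=O)O)nn(-c2ccccc2)c1-c1ccc(F)cc1`) gives > 680000 nM as a limit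

Compound 3 has no real number to its name. Its reading of > 680000 nM is a limit of the assay, and its other entries give no single number either.

Compound 4 (`CC(C)(C)NCc1c(C(=O)O)nn(-c2ccccc2)c1-c1ccc(Cl)cc1`) differs from compound 3 at one spot only: chloro in place of fluoro on an aromatic carbon is the whole change, chloro in place of fluoro on an aromatic carbon, para to a large group. The 4-fluorophenyl thus becomes 4-chlorophenyl.

The other compounds offer thin guidance. For compound 2 the record the several entries of compound 2 in this assay, 69200 nM; > 559000 nM (2 entries) holds one number and one limit, so it settles little.

No step beyond the usual scatter is expected in this assay and no direction can be named with confidence. The estimated step of an at least 1.3-fold lower number from compound 3 to compound 4 (0.13 log units; that floor lies within the scatter) is expected to be small. For compound 4 the estimate is 500000 nM with an expected range of 150000 nM to 1000000 nM and a reading that is only a limit is quite possible.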

Compound 4, concentration for 50% growth inhibition: 70500 nM
Beside the measured number, compound 4's estimate is 7.1-fold (0.85 log units) above it; the whole stated range lies above it.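

In this assay, chloro in place of fluoro on this aromatic carbon, para to a large group, gives an at least 9.6-fold lower number from compound 3 to compound 4 (0.98 log units; beyond the scatter). Going by these compounds alone, this is the first step at this position that can be read with a direction and a floor for its size, and it shows that this single-atom change can matter when the carboxylic acid is present. The same change between the ethyl esters gives no such reading, since compound 2, the chloro partner of compound 1, has one number and one limit on record: the several entries of compound 2 in this assay, 69200 nM; > 559000 nM (2 entries). Only the floor of the new step is known, since the reading of compound 3 is a limit: the limit of > 680000 nM in this assay, at which 1 of the 4 values shown sits.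

The compounds shown leave open whether bromo or methoxy on this carbon would give a lower number than compound 4 or a reading closer to that of compound 3. They also leave open whether chloro brings the same gain when the ethyl ester stands in place of the carboxylic acid, and whether a group other than tert-butyl on the amine would change the picture.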